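The source may hold more compounds than are shown below. What is called first, only, known or untested is meant among the compounds shown, and "the series" means these compounds.

Working notes on the coumarin ester series

Compound 1 `COc1cc2ccc(=O)oc2cc1OC(=O)c1c(C)noc1-c1ccccc1` carries a phenyl group on its ester-linked five-membered ring, and in a functional assay on SW-620 cells (Homo sapiens) for inhibition, read by MTT assay, with a stated time of 48 h (a higher number here means a weaker inhibitor, a lower number a stronger inhibitor), compound 1 gives 23400 nM. Compound 2 `COc1cc2ccc(=O)oc2cc1OC(=O)c1c(C)noc1-c1ccc([N+](=O)[O-])cc1` differs from compound 1 only by nitro in place of hydrogen on an aromatic carbon; in this assay compound 2 gives 9830 nM. The step of a 2.4-fold lower number from compound 1 to compound 2 (0.38 log units; beyond the scatter) is therefore a real but modest gain in potency.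

Compound 3 `COc1cc2ccc(=O)oc2cc1OC(=O)c1c(-c2ccccc2)n[nH]c1C` has a different core from compound 1; how the two cores differ is not broken down here. In this assay the value of compound 3 is only a limit of the assay, > 25000 nM, as described by the limit of > 25000 nM in this assay, at which 1 of the 3 values shown sits.

Compound 4 `COc1cc2ccc(=O)oc2cc1OC(=O)c1c(-c2ccc([N+](=O)[O-])cc2)n[nH]c1C` is not yet measured. It differs from compound 3 by nitro in place of hydrogen on an aromatic carbon, which is the same change as that from compound 1 to compound 2, made at the same kind of place on the same phenyl group. The change has been seen once only, so its size rests on a single measured step.

For compound 4 in this assay the expected step is an at least 1.3-fold lower number from compound 3 to compound 4 (0.14 log units; that floor lies within the scatter), taken as a copy of the measured step of a 2.4-fold lower number from compound 1 to compound 2 (0.38 log units; beyond the scatter) applied to a starting point that is itself only a limit; compound 4 is therefore estimated at 18000 nM, with a likely range from 9000 nM to 40000 nM, and a real chance that the assay again reports only a limit for compound 4.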

Compound 4, half-maximal inhibitory concentration: > 25000 nM
Compound 4: no number, only a limit; the forecaster's own chance of this, stated with the estimate: 35%; middle value at least 1.3-fold (0.14 log units) from the limit.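

In this assay compound 4 gives > 25000 nM as a limit of the assay and not a number. Compound 3 also stands at a limit, so no step can be read between compound 3 and compound 4: the limit of > 25000 nM in this assay, at which 2 of the 4 values shown sit.

From the compounds shown here alone, what stays open is whether nitro in place of hydrogen on the phenyl group changes the number at all on the core of compound 3, as it does on the core of compound 1.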